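The compounds below may be only part of what the source reports. "The series", "measured", "known", "first", "only" and "open" are said of these compounds alone.

Measured compounds:
compound 1 `CCCn1ccc2c(NCc3cccc(OC)c3)cccc2c1=O`: 316 nM
compound 2 `CCCn1ccc2c(NCc3cccc(Oc4ccccc4)c3)cccc2c1=O`: 1260 nM

Both compounds share one core and differ only in the group attached to the oxygen on the aromatic ring. Going by the values given here, in a functional assay on CHO cells for positive allosteric modulation of metabotropic glutamate receptor 2 (Homo sapiens), read by scintillation counting and GTPgammaS binding, with a stated time of 30 min (a higher number here means that more compound is needed for the effect, a lower number that less compound is needed), compound 2 carries the higher of the two numbers, and compound 1 is its only neighbour. Among the compounds with values here, the single measured step at this position is a 4.0-fold higher number from compound 1 to compound 2 (0.60 log units; beyond the scatter), where a phenyl took the place of a methyl on that oxygen, so enlarging the group at this point made more compound necessary.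

Compound 3 `CCCn1ccc2c(NCc3cccc(OC(F)(F)F)c3)cccc2c1=O` differs from compound 2 by trifluoromethyl in place of phenyl on an oxygen on an aromatic ring. This change moves back toward the small group of compound 1 without fully restoring it, so a partial reversal of the step from compound 1 to compound 2 is expected, meaning a lower number in this assay, though perhaps not as low as compound 1. Compound 3 is therefore estimated at 500 nM, in a range from 200 nM to 1500 nM. This estimate corresponds to an expected step of a 2.5-fold lower number from compound 2 to compound 3 (0.40 log units; beyond the scatter).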

Compound 3, half-maximal effective concentration: 200 nM
Estimate against measurement, compound 3: 2.5-fold (0.40 log units) above; measured number inside the range.
By their numbers in this assay, from the lowest: compounds 3 and 1 (each within the scatter of the next); then compound 2.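

In this assay, replacing the phenyl of compound 2 with trifluoromethyl gives a 6.3-fold lower number from compound 2 to compound 3 (0.80 log units; beyond the scatter), so the penalty seen with phenyl does not persist once that ring is gone. Set against the methyl group, trifluoromethyl gives a 1.6-fold lower number from compound 1 to compound 3 (0.20 log units; within the scatter), which means that compound 1 and compound 3 cannot be told apart and that this position accepts fluorine in place of the hydrogens of the methyl group without a measurable change. Nothing available explains why these groups on the oxygen behave as they do.

Going by these compounds alone, with only three groups compared, it remains open whether an ethyl, a longer chain or a benzyl on this oxygen would behave like methyl and trifluoromethyl or like phenyl. A free hydroxyl on the aromatic ring, or an amine in place of the oxygen, also remains to be placed in this picture.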